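Aryl esters of the dimethyl lactone core: para substituent

The source may report more compounds than this note shows. Statements on the series, on what has been measured and on what is new or still open speak of the compounds shown alone.

Compound 1 `CCCCCC(=O)O[C@H]1C(=O)OCC1(C)C` carries a hexanoyl ester on the shared core; in an assay on isolated protein for inhibition of fatty acid synthase (Mus musculus), read by spectrophotometry, using NADPH, with stated times of 30 min and 3 min, in the presence of a further agent that is not named here (on this read-out lower numbers stand for stronger inhibition and higher numbers for weaker inhibition), compound 1 gives 23300 nM. Compound 2 `CC1(C)COC(=O)[C@@H]1OC(=O)c1ccccc1` bears the unsubstituted benzoate, and in this assay compound 2 gives 23000 nM. Compound 3 `CC1(C)COC(=O)[C@@H]1OC(=O)c1ccc(Cl)cc1` adds chloro to that benzoate, and in this assay compound 3 gives 19200 nM. Compound 3 shows the lowest of the three numbers, but all three lie within the scatter of one another, so no order among them can be read. Among the compounds with values here, the one step, a 1.2-fold lower number from compound 2 to compound 3 (0.08 log units; within the scatter), is itself within the scatter.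

Compound 4 `COc1ccc(C(=O)O[C@H]2C(=O)OCC2(C)C)cc1` differs from compound 3 by methoxy in place of chloro on an aromatic carbon. Within the data shown here, the only step that bears on this change is the one from compound 2 to compound 3, which was within the scatter, so a swap of one small group for another at the same place is expected to give no shift beyond the scatter in this assay. Compound 4 is therefore expected at 21000 nM, within 8000 nM to 50000 nM, which means an expected step of a 1.1-fold higher number from compound 3 to compound 4 (0.04 log units; within the scatter).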

Compound 4, half-maximal inhibitory concentration: 13700 nM
Compound 4: the middle estimate sits 1.5-fold (0.19 log units) above what was measured; the range from low to high includes it.
By their numbers in this assay, from the lowest: compounds 4, 3, 2 and 1 (each within the scatter of the next).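

In this assay, methoxy at the place on the aromatic carbon para to a large group gives a 1.4-fold lower number from compound 3 to compound 4 (0.15 log units; within the scatter) when it replaces chloro and a 1.7-fold lower number from compound 2 to compound 4 (0.23 log units; within the scatter) when it replaces hydrogen. This place has therefore now carried hydrogen, chloro and methoxy with no listed step beyond the scatter, even though methoxy has a hydrogen-bond acceptor that chloro lacks and more heavy atoms. No measurement at hand bears on why these steps stay so small.

From the compounds shown here alone, it remains open whether an amine, a carboxylic acid or a nitrile at this same place would give a step beyond the scatter. Going by these compounds, it also remains open whether any change to the ester on the shared core, such as a longer chain than hexanoyl, would move the number beyond the scatter.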